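Bromo for methoxy on a pyrimidine-aniline antiproliferative series

This account rests on a few compounds, and the source may have more. Where it says the series, first, only, none or still open, it means among the compounds named here.

Compound 1 `COc1ccc(-c2ccnc(Nc3ccc(Cl)cc3Cl)n2)cc1`: 23000 nM
Compound 2 `CC(C)c1ccccc1Nc1nccc(-c2ccc(Br)cc2)n1`: 11500 nM
Compound 3 `Clc1ccc(Nc2nccc(-c3ccc(Cl)cc3Cl)n2)c(Cl)c1`: 1560 nM

Of the compounds shown here, three sharing one core have been tested in a functional assay on HeLa cells (Homo sapiens) for antiproliferative activity, read by MTT assay; on this read-out lower numbers stand for stronger inhibition and higher numbers for weaker inhibition. Compound 1 `COc1ccc(-c2ccnc(Nc3ccc(Cl)cc3Cl)n2)cc1` gives 23000 nM in this assay, the highest of the three numbers. Compound 2 `CC(C)c1ccccc1Nc1nccc(-c2ccc(Br)cc2)n1` gives 11500 nM, which lies within the scatter of the value of compound 1, so the two cannot be put in order. Compound 3 `Clc1ccc(Nc2nccc(-c3ccc(Cl)cc3Cl)n2)c(Cl)c1` gives 1560 nM, well beyond the scatter from compound 1 and thus the clearly stronger of that pair.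

Compound 4 `Clc1ccc(Nc2nccc(-c3ccc(Br)cc3)n2)c(Cl)c1` has not yet been measured in this assay. Compared with compound 1 it carries bromo in place of methoxy on an aromatic carbon, on an aromatic carbon of a six-membered aromatic ring of carbon only, para to a large group. For the measured compounds named here, no step between measured compounds isolates this change, so the size of the step from compound 1 to compound 4 is an open question. Compound 4 carries the same aniline part as compound 3 and the same bromophenyl part as compound 2, and both of these compounds sit below compound 1 in this assay. The step of a 4.6-fold lower number from compound 1 to compound 4 (0.66 log units; beyond the scatter) is therefore expected to go toward a lower number, by more than the scatter. Compound 4 is estimated at 5000 nM, within 1500 nM to 16000 nM.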

Compound 4, half-maximal inhibitory concentration: 1080 nM
Compound 4: the middle estimate sits 4.6-fold (0.67 log units) above what was measured; the measured number lies below the stated range.
By their numbers in this assay, from the lowest: compounds 4 and 3 (each within the scatter of the next); then compounds 2 and 1 (each within the scatter of the next).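

In this assay, bromo in place of methoxy on the aromatic carbon para to a large group gives a 21-fold lower number from compound 1 to compound 4 (1.33 log units; beyond the scatter) and so supplies the series' first step that isolates a single change. It shows that this position is not indifferent to its substituent, since this one exchange, with the rest of the molecule held constant, moves the number by far more than the scatter. The exchange removes two heavy atoms, one carbon and one oxygen, together with one hydrogen-bond acceptor, and introduces one bromine atom with no acceptor, but nothing available explains why the number falls so far.

The compounds shown leave open whether the gain belongs to bromo specifically or whether other groups at this position, such as an amine, a hydroxy group or a nitrile, would give a similar number. For the compounds shown here, they also leave open whether the same exchange would have a step of similar size on a different aniline part, as only this one pair isolates it.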